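The compounds below may be only part of what the source reports. "The series", "measured", "known", "first", "only" and "open" are said of these compounds alone.

In a physicochemical assay for solubility, read by HPLC, using the shake flask method, in phosphate buffer, with a stated time of 20 h, at pH 6.5 (a lower number here means a less soluble compound, a higher number a more soluble compound), compound 1 `CN1CCN(CC2CCN(c3nccc4[nH]c(-c5ccc(F)c(F)c5)nc34)CC2)CC1` gives 195000 nM, compound 2 `CN1CCN(CC2CCN(c3nccc4[nH]c(-c5ccc(F)c(Cl)c5)nc34)CC2)CC1` gives 155000 nM and compound 3 `CN1CCN(CC2CCN(c3nccc4[nH]c(-c5cccc(OCCN)c5)nc34)CC2)CC1` gives 200000 nM. Compound 3 therefore cannot be told apart from the other two on these numbers. Compound 4 `CN1CCN(CC2CCN(c3nccc4[nH]c(-c5cccc(C(=O)O)c5)nc34)CC2)CC1` has carboxy in place of 2-aminoethoxy on an aromatic carbon. Among the compounds with values here, no measured compound carries a carboxy group, so the closest evidence comes from other changes to this aromatic group: a 1.0-fold higher number from compound 1 to compound 3 (0.01 log units; within the scatter), a 1.3-fold higher number from compound 2 to compound 3 (0.11 log units; within the scatter) and, for chloro in place of fluoro, a 1.3-fold lower number from compound 1 to compound 2 (0.10 log units; within the scatter). With all three steps within the scatter, no step beyond the scatter is expected in this assay. The expected step is a 1.1-fold lower number from compound 3 to compound 4 (0.05 log units; within the scatter). For compound 4, the estimated value is 180000 nM, with an expected range from 80000 nM to 400000 nM.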

Compound 4, solubility: 195000 nM
Compound 4: middle estimate off by 1.1-fold (0.03 log units), on the low side; measured number inside the range.
By their numbers in this assay, from the lowest: compounds 2, 1, 4 and 3 (each within the scatter of the next).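

Carboxy on this aromatic carbon, meta to a large group, gives a 1.0-fold lower number from compound 3 to compound 4 (0.01 log units; within the scatter) in this assay. Set against the halogen-bearing compounds, the same group gives a 1.3-fold higher number from compound 2 to compound 4 (0.10 log units; within the scatter) and no change at the digits printed from compound 1 to compound 4 (within the scatter), so a carboxy group joins 2-aminoethoxy and the halogens in a set of four that cannot be told apart here. No measurement shown accounts for this. Still open, from the compounds shown here alone, is whether an amide, or a longer chain ending in a carboxylic acid, on this carbon would stand apart from these four.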